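Swapping the Aryl Group on a Sulfonyl Sulfur

The source may hold more compounds than are shown below. What is called first, only, known or untested is meant among the compounds shown, and "the series" means these compounds.

Three compounds have been measured in a functional assay on LNCaP cells (Homo sapiens) for antiproliferative activity, read by fluorescence and propidium iodide staining, with a stated time of 96 h; on this read-out lower numbers stand for stronger inhibition and higher numbers for weaker inhibition:
compound 1, `CC(O)(CSc1ccccc1C(F)(F)F)C(=O)Nc1cc(C(F)(F)F)cc(C(F)(F)F)c1`, gives 3570 nM
compound 2, `CC(O)(CSc1cccc(OC(F)(F)F)c1)C(=O)Nc1cc(C(F)(F)F)cc(C(F)(F)F)c1`, gives 7760 nM
compound 3, `CC(O)(CS(=O)(=O)c1ccccc1C(F)(F)F)C(=O)Nc1cc(C(F)(F)F)cc(C(F)(F)F)c1`, gives 8510 nM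

Compound 4, `CC(O)(CS(=O)(=O)c1cccc(OC(F)(F)F)c1)C(=O)Nc1cc(C(F)(F)F)cc(C(F)(F)F)c1`, is not yet measured. It differs from compound 3 by 3-(trifluoromethoxy)phenyl in place of 2-(trifluoromethyl)phenyl on a sulfonyl sulfur. Compound 2 differs from compound 1 by 3-(trifluoromethoxy)phenyl in place of 2-(trifluoromethyl)phenyl on a sulfur, and that change gave a 2.2-fold higher number from compound 1 to compound 2 (0.34 log units; beyond the scatter). The two changes are the same kind of change, but the place differs: in compound 1 the group sits on a sulfur whose other neighbours are saturated chain carbon, in compound 3 on a sulfonyl sulfur whose other neighbours are saturated chain carbon. The difference between the two cores is not broken down here. A similar step is expected, a 1.9-fold higher number from compound 3 to compound 4 (0.27 log units; within the scatter), because the same kind of change gave a 2.2-fold higher number from compound 1 to compound 2 (0.34 log units; beyond the scatter). For compound 4 the expected value is 16000 nM, estimated between 7000 nM and 36000 nM.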

Compound 4, half-maximal inhibitory concentration: 9340 nM
Beside the measured number, compound 4's estimate is 1.7-fold (0.23 log units) above it; the measured number falls inside the stated range.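

In this assay, placing 3-(trifluoromethoxy)phenyl instead of 2-(trifluoromethyl)phenyl on the sulfonyl sulfur gives a 1.1-fold higher number from compound 3 to compound 4 (0.04 log units; within the scatter). Set beside the same swap on the plain sulfur of the other core, the two steps are no further apart than repeat measurements could make them: the same change on two cores in this assay, a 2.2-fold higher number (0.34 log units; beyond the scatter) from compound 1 to compound 2 and a 1.1-fold higher number (0.04 log units; within the scatter) from compound 3 to compound 4, 2.0-fold (0.30 log units) apart, within the scatter of two such steps. The change therefore carries from one core to the other without a detectable difference between the cores, but two pairs do not show that its size is truly the same on both, or that it would hold on any further core.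

The compounds shown leave open how other groups on the aromatic ring, such as a nitrile or an amine, would behave. They also leave open what a sulfoxide would give in place of the sulfur or the sulfonyl.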